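Removing the pyrazole: a bare amino group on the shared core

A few compounds are considered here, and "the series" means these few. Any claim that something is new, unique, unknown or untested is made for them only; others in the source may bear on it.

Of the compounds shown here, three with the same core have been measured in an assay on isolated protein for inhibition of Leucine-rich repeat serine/threonine-protein kinase 2 (Homo sapiens), read by TR-FRET and LanthaScreen, with stated times of 50 min and 30 min, in the presence of a further agent that is not named here; a lower number here means a stronger inhibitor, a higher number a weaker inhibitor. Compound 1 `C[C@@H]1CCCN1c1c(C#N)c2c(N)nc(Nc3cn(C)nc3C(F)(F)F)nc2n1C` gives 508 nM, compound 2 `Cc1c(Nc2nc(N)c3c(C#N)c(N4CCC[C@H]4C)n(C)c3n2)cnn1C1COC1` gives 47 nM, and compound 3 `Cc1n[nH]cc1Nc1nc(N)c2c(C#N)c(N3CCC[C@H]3C)n(C)c2n1` gives 42 nM. Compound 3 has the lowest number of the three, but its gap to compound 2 is within the scatter, so the two cannot be separated; only compound 1 stands clearly apart, as seen in an 11-fold lower number from compound 1 to compound 2 (1.03 log units; beyond the scatter) and a 12-fold lower number from compound 1 to compound 3 (1.08 log units; beyond the scatter).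

Compound 4 `C[C@@H]1CCCN1c1c(C#N)c2c(N)nc(N)nc2n1C` differs from compound 3 in one place: hydrogen in place of 3-methyl-1H-pyrazol-4-yl on a nitrogen on an aromatic ring. Every measured step exchanged one pyrazole for another and kept a ring on that nitrogen; none removed it. The two large steps from compound 1 show that what sits on this nitrogen changes the number considerably, so the step to nothing at all is expected to matter, and most plausibly in the direction of a weaker inhibitor, with real uncertainty. In this assay compound 4 is therefore expected at 3000 nM, within 400 nM to 20000 nM, a step of a 71-fold higher number from compound 3 to compound 4 (1.85 log units; beyond the scatter).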

Compound 4, half-maximal inhibitory concentration: 248 nM
For compound 4 the middle estimate is 12-fold (1.08 log units) above the measured one; the measured number lies below the stated range.
By their numbers in this assay, from the lowest: compounds 3 and 2 (each within the scatter of the next); then compound 4; then compound 1.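

Taking the ring off this nitrogen does not push the number in one direction: in this assay the change to a bare amino group gives a 5.9-fold higher number from compound 3 to compound 4 (0.77 log units; beyond the scatter) and a 5.3-fold higher number from compound 2 to compound 4 (0.72 log units; beyond the scatter), yet a 2.0-fold lower number from compound 1 to compound 4 (0.31 log units; beyond the scatter) runs the other way. A ring on this nitrogen is therefore not needed for inhibition, and whether one helps depends on the ring, as the 1-methyl-3-(trifluoromethyl)-1H-pyrazol-4-yl of compound 1 goes against the other two pyrazoles. Nothing available here gives a reason for this split.

Going by these compounds, it remains open whether a small open-chain group on this nitrogen, such as ethyl or 2-methoxyethyl, would stay close to compound 4 or approach compound 3. A ring of another kind, such as a piperidine or a phenyl, is equally untested in what is shown.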